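Methyl for isopropyl on the ring amine: half-life notes

The source may hold more compounds than are shown below. What is called first, only, known or untested is meant among the compounds shown, and "the series" means these compounds.

Compound 1 `CC(C)N1CC(=O)N=C1NC(=N)Nc1ccc(Cl)c(Cl)c1` and compound 2 `CN1CC(=O)N=C1NC(=N)Nc1ccc(Cl)c(Cl)c1` share a core; compound 3 `CC(C)N1CC(=O)N=C1N/C(=N\C(=O)OC(C)(C)C)Nc1ccc(Cl)c(Cl)c1` and compound 4 `CN1CC(=O)N=C1N/C(=N\C(=O)OC(C)(C)C)Nc1ccc(Cl)c(Cl)c1` share another, and the difference between the two cores is not broken down here. In an in vivo ADME assay on the whole organism for metabolic stability, with Mus musculus as the target, read by LC-MS, at a dose of 160 mg/kg by the oral route (on this read-out higher numbers stand for a longer-lived compound and lower numbers for a shorter-lived compound), compound 1 gives 0.667 h. Compound 2 gives > 1 h in this assay, which is a limit of the assay and not a number. The change methyl in place of isopropyl on an amine nitrogen in a ring therefore gave an at least 1.4-fold higher number from compound 1 to compound 2 (0.17 log units; that floor lies within the scatter), a floor resting on (the limit of > 1 h in this assay, at which 1 of the 3 values shown sits). In this assay compound 3 gives 0.263 h, the lowest of the two numbers. The change methyl in place of isopropyl on an amine nitrogen in a ring is the same change at the same place. From compound 3 to compound 4 a step of a 1.5-fold higher number from compound 3 to compound 4 (0.18 log units; within the scatter) is expected in this assay, because compound 1 to compound 2 showed an at least 1.4-fold higher number from compound 1 to compound 2 (0.17 log units; that floor lies within the scatter). Compound 4 is thus estimated at 0.4 h, between 0.2 h and 0.9 h.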

Compound 4, half-life: < 0.167 h
Compound 4 was reported as a limit (the forecaster's own chance of this, stated with the estimate: 10%); middle value at least 2.3-fold (0.37 log units) from the limit.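

Carried to the second core, methyl in place of isopropyl on the amine nitrogen in the ring gave an at least 1.5-fold lower number from compound 3 to compound 4 (0.19 log units; that floor lies within the scatter). Compound 4 gives < 0.167 h in this assay, which is a limit of the assay and not a number. The two steps are printed in opposite directions, yet both rest on limits, so this shows neither that the change carries over unchanged nor that the cores respond differently: the same change on two cores in this assay, an at least 1.4-fold higher number (0.17 log units; that floor lies within the scatter) from compound 1 to compound 2 and an at least 1.5-fold lower number (0.19 log units; that floor lies within the scatter) from compound 3 to compound 4; the limit leaves it open whether they differ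

The compounds shown leave open the true size of each step, with compound 2 and compound 4 both at limits. They also leave open how the half-life responds on either core to another group on this nitrogen, such as ethyl or a longer chain.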